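A few compounds are considered here, and "the series" means these few. Any claim that something is new, unique, unknown or untested is made for them only; others in the source may bear on it.

Measured so far:
Compound 1, `CC(C)c1ccc(NC(=O)N[C@@H](C)c2ccccc2)cc1`: 98%
Compound 2, `CCCCc1ccc(NC(=O)N[C@@H](C)c2ccccc2)cc1`: 98%
Compound 3, `CCCCCCCc1ccc(NC(=O)N[C@@H](C)c2ccccc2)cc1`: 100%

In an ADME assay on the whole organism with Oryza sativa as the target, tested at 0.1 uM (on this read-out lower numbers stand for a stronger effect and higher numbers for a weaker effect at the one concentration tested), compound 3 gives 100%, the highest of the three numbers; its distance to the others is a number 2 percentage points higher from compound 1 to compound 3 (within the scatter) and a number 2 percentage points higher from compound 2 to compound 3 (within the scatter), both within the scatter, so the three compounds are not distinguishable on this read-out.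

Compound 4, `CC(=O)c1ccc(NC(=O)N[C@@H](C)c2ccccc2)cc1`, differs from compound 3 in one place: acetyl in place of heptyl on an aromatic carbon.

The measured steps all swap one alkyl chain for another on the same aromatic carbon, no change at the digits printed from compound 1 to compound 2 (within the scatter) and the two above, and none moves the read-out beyond the scatter. Going by the values given here, none of them puts a carbonyl there, so there is no direct precedent; given that nothing has shifted this assay, no step beyond the scatter is expected, a number 4 percentage points lower from compound 3 to compound 4 (within the scatter), with wider uncertainty than for the alkyl swaps.

Compound 4 is therefore estimated at 96%, expected between 80% and 100%.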

Compound 4, a percentage reported as activity, at one concentration (the size of the read-out at that concentration, not a potency): 99%
Compound 4: the middle estimate sits 3 percentage points below what was measured; the range from low to high includes it.
By their numbers in this assay, from the lowest: compounds 1, 2, 4 and 3 (each within the scatter of the next).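

In this assay acetyl on this aromatic carbon gives a number 1 percentage points lower from compound 3 to compound 4 (within the scatter) and a number 1 percentage points higher from compound 2 to compound 4 (within the scatter) and a number 1 percentage points higher from compound 1 to compound 4 (within the scatter) so a group carrying a carbonyl and a hydrogen-bond acceptor is not told apart from the alkyl groups here. The series now spans more than alkyl swaps at this position, and the read-out still shows no step beyond the scatter. Nothing available accounts for this result.

As far as these compounds go, whether an amine or a carboxylic acid on this aromatic carbon would shift the read-out remains open. So does the effect of any change elsewhere on the shared core.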